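The source may hold more compounds than are shown below. What is called first, only, known or untested is meant among the compounds shown, and "the series" means these compounds.

Compound 1 `COc1cc2c(Oc3ccc(NC(=O)c4nn(-c5ccc(Br)cc5)c(=O)c5ccccc45)cc3F)ccnc2cc1OCCCN1CCCC1` and compound 2 `COc1cc2c(Oc3ccc(NC(=O)c4nn(-c5ccc([N+](=O)[O-])cc5)c(=O)c5ccccc45)cc3F)ccnc2cc1OCCCN1CCCC1` share one core and differ only in the group on the outer aromatic ring. In a functional assay on HT-29 cells (Homo sapiens) for cytotoxicity, read by MTT assay, with a stated time of 72 h (a higher number here means a weaker inhibitor, a lower number a stronger inhibitor), compound 1 gives 670 nM. In this assay, for the measured compounds named here, compound 2 gives 1760 nM, which is the higher of the two numbers measured so far, its nearest neighbour being compound 1. Going by the values given here, the one step measured between them is a 2.6-fold higher number from compound 1 to compound 2 (0.42 log units; beyond the scatter), a change at the aromatic end of the molecule.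

Compound 3 `COc1cc2c(Oc3ccc(NC(=O)c4nn(-c5ccc([N+](=O)[O-])cc5)c(=O)c5ccccc45)cc3F)ccnc2cc1OCCCN1CCN(C)CC1` is not yet measured. It differs from compound 2 in one place: 4-methylpiperazin-1-yl in place of pyrrolidin-1-yl on a saturated chain carbon, three bonds along the chain from an oxygen on an aromatic ring. Among the compounds with values here, no measured step touches this end of the chain; the only step on record, a 2.6-fold higher number from compound 1 to compound 2 (0.42 log units; beyond the scatter), sits at the opposite end and says nothing about the ring on the chain. Within the data shown here, with no step bearing on the change, the expectation is for no step beyond the usual scatter, so the estimated step is a 1.0-fold lower number from compound 2 to compound 3 (0.02 log units; within the scatter). Compound 3 is therefore expected to give about 1700 nM, within a range from 600 nM to 5000 nM.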

Compound 3, half-maximal inhibitory concentration: 2560 nM
Compound 3: middle estimate off by 1.5-fold (0.18 log units), on the low side, within the range that was stated.
By their numbers in this assay, from the lowest: compound 1; then compounds 2 and 3 (each within the scatter of the next).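

For the compounds shown here, this is the first change measured at the far end of the chain, and in this assay replacing pyrrolidin-1-yl with 4-methylpiperazin-1-yl gives a 1.5-fold higher number from compound 2 to compound 3 (0.16 log units; within the scatter), so the two compounds cannot be told apart. With the nitro group on the outer aromatic ring, exchanging the five-membered non-aromatic ring for the six-membered one therefore leaves no reading beyond the scatter, whereas the change at the aromatic end, a 2.6-fold higher number from compound 1 to compound 2 (0.42 log units; beyond the scatter), does go beyond it. Nothing available explains the small size of this step or links it to any feature of either ring.

What the compounds shown leave open is whether the same exchange reads the same way when bromo replaces the nitro group, since this position is seen only in one pair that carries nitro. They also leave open how morpholin-4-yl, dimethylamino or a primary amine would read at the end of the chain, and whether a butyl linker in place of the propyl chain would shift the number in this assay.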